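This account rests on a few compounds, and the source may have more. Where it says the series, first, only, none or still open, it means among the compounds named here.

Working notes on the series. Compound 2 `N#C/C(=C\c1cccc(Br)n1)C(=O)N[C@@H](CO)c1ccccc1` was tested in a functional assay on OCI-My4 cells (Homo sapiens) for antiproliferative activity, read by MTT assay, with a stated time of 72 h (a lower number here means a stronger inhibitor, a higher number a weaker inhibitor), and gives 3900 nM. Compound 1 `C[C@H](NC(=O)/C(C#N)=C/c1cccc(Br)n1)c1ccc(Br)cc1` gives 2000 nM in the same assay. For the measured compounds named here, of the two numbers so far, compound 2 has the higher one, but its gap to compound 1 lies within the scatter, so the two readings are not separated.

The next compound in the series, compound 3 `CC[C@H](NC(=O)/C(C#N)=C/c1cccc(Br)n1)c1ccccc1`, is not yet measured in this assay. It differs from compound 2 in one place: methyl in place of hydroxy on a saturated chain carbon, two bonds along the chain from an amide-type nitrogen and an aromatic carbon. Going by the values given here, no pair of measured compounds shows this particular change, so no measured step can be leaned on. Among the compounds with values here, the only related reading is compound 1, which carries a methyl at the corresponding chain carbon together with a further bromo substituent, and gives 2000 nM, a value that sits within the scatter of compound 2.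

On that footing the step is expected to be small, in either direction, and not beyond the scatter: the estimated step is a 1.4-fold lower number from compound 2 to compound 3 (0.14 log units; within the scatter). Compound 3 is therefore estimated at 2800 nM, with a range from 900 nM to 9000 nM.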

Compound 3, half-maximal inhibitory concentration: 1700 nM
For compound 3 the middle estimate is 1.6-fold (0.22 log units) above the measured one; the range from low to high includes it.
By their numbers in this assay, from the lowest: compounds 3, 1 and 2 (each within the scatter of the next, the first and the last beyond it).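

For the compounds shown here, the exchange of hydroxy for methyl, on a saturated chain carbon, two bonds along the chain from an amide-type nitrogen and an aromatic carbon, provides the first single-place step: in this assay it gives a 2.3-fold lower number from compound 2 to compound 3 (0.36 log units; beyond the scatter). The step is modest, but it shows that, in this pair, the hydroxymethyl group can be replaced by ethyl without loss of antiproliferative activity, so the hydroxy is not required at this position for the activity read here. No accompanying measurement accounts for the step, and its origin remains unexplained.

Going by these compounds, it remains open whether the step reflects the removal of the hydroxy or the presence of the ethyl; an aminomethyl group, a carboxylic acid or a longer chain such as propyl at the same chain carbon would help separate the two. Also unresolved is whether the same exchange gives a step of similar size and direction when the compounds carry a further bromo substituent, as compound 1 does.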